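A few compounds are considered here, and "the series" means these few. Any claim that something is new, unique, unknown or untested is made for them only; others in the source may bear on it.

Measured compounds:

compound 1, `O=C(O)/C=C/c1ccncc1-c1ccc2cc[nH]c2c1`, gives > 30000 nM
compound 2, `COC1CN(C(=O)/C=C/c2ccncc2-c2ccc3ccccc3c2)C1`, gives > 30000 nM
compound 3, `CNC(=O)/C=C/c1ccncc1-c1ccc2[nH]ccc2c1`, gives > 30000 nM

All three were tested in a functional assay on HCT-116 cells (Homo sapiens) for inhibition, read by MTT assay, with a stated time of 72 h; on this read-out higher numbers stand for weaker inhibition of growth and lower numbers for stronger inhibition of growth. For compound 1 the reading > 30000 nM is a limit of the assay, not a number. For compound 2 the reading > 30000 nM is likewise a limit. For compound 3 the reading > 30000 nM is also a limit. Compound 2 therefore stands nowhere in particular on a scale: it sits with the others at the limit of > 30000 nM in this assay, at which 3 of the 3 values shown sit, and no one of these three can be set above or below another.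

The next compound, compound 4, `COC(=O)/C=C/c1ccncc1-c1ccc2ccccc2c1`, is not yet measured in this assay. It differs from compound 2 in one place: methoxy in place of 3-methoxyazetidin-1-yl on a carbonyl carbon. The amide built on the 3-methoxyazetidin-1-yl group becomes a plain methoxycarbonyl ester on the same carbonyl carbon whose other neighbour is a double-bonded chain carbon.

Going by the values given here, with every measured compound at the limit, there is no measured step to lean on. The shared core with its side chain has given no measurable growth inhibition in any of compounds 1, 2 or 3, so the change from compound 2 to compound 4 is expected to produce a number no higher from compound 2 to compound 4 (the limit leaves the size open), that is, no step beyond the scatter. Compound 4 is expected to give about 30000 nM, within a range from 10000 nM to 100000 nM, and most likely the assay will again report only a limit.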

Compound 4, concentration for 50% growth inhibition: 350 nM
Compound 4: middle estimate off by 86-fold (1.93 log units), on the high side; the measured number lies below the stated range.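

In this assay, the group on this carbonyl carbon proves able to decide whether growth inhibition can be measured at all: methoxy in place of 3-methoxyazetidin-1-yl gives an at least 85-fold lower number from compound 2 to compound 4 (1.93 log units; beyond the scatter). For compound 2 the reading > 30000 nM is a limit of the assay, not a number, so the step has a known minimum but no known full size. The earlier compounds could not show that this position responds to change, since none of them gave a number: the limit of > 30000 nM in this assay, at which 3 of the 4 values shown sit.

The compounds shown leave open whether the gain follows from the ester oxygen on the carbonyl carbon or from the loss of the four-membered ring, since the change from compound 2 to compound 4 alters both at once. An ethoxy group or a dimethylamino group on the same carbonyl carbon would help separate these two readings, while compound 1 and compound 3 cannot, for each differs from compound 4 in more than one place.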